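Lengthening the sulfamide chain on an inactive parent

The source may hold more compounds than are shown below. What is called first, only, known or untested is meant among the compounds shown, and "the series" means these compounds.

Compound 1 `COc1ccc(-c2cc(N3CCC(CNS(N)(=O)=O)CC3)ncn2)cc1` is the starting point. In a functional assay on HT-29 cells (Homo sapiens) for antiproliferative activity, read by sulforhodamine B assay, with a stated time of 48 h (a higher number here means a weaker inhibitor of growth, a lower number a stronger inhibitor of growth), compound 1 gives only a limit of the assay, > 100000 nM, so its true value is not known. The same limit recurs across the set: the limit of > 100000 nM in this assay, at which 2 of the 3 values shown sit. Two neighbours show what a change elsewhere in the molecule can do. Compound 2 `CCOC(=O)c1ccc(-c2cc(N3CCC(CNS(N)(=O)=O)CC3)ncn2)cc1` in this assay gives 5700 nM, and the step of an at least 17-fold lower number from compound 1 to compound 2 (1.24 log units; beyond the scatter) shows that a single change on the aromatic ring can carry the series from the limit into measurable territory. Compound 3 `NS(=O)(=O)NCC1CCN(c2cc(-c3ccccc3Cl)ncn2)CC1` in this assay again gives only a limit, > 100000 nM. The step that the two limits leave unreadable from compound 1 to compound 3 therefore tells nothing about direction or size.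

Compound 4 `COc1ccc(-c2cc(N3CCC(CCNS(N)(=O)=O)CC3)ncn2)cc1` differs from compound 1 in the chain that carries the sulfamide: (sulfamoylamino)methyl in place of sulfamoylamino on a saturated chain carbon bound to a saturated ring carbon. Among the measured compounds shown here, neither measured step touches this chain; both alter the aryl substituent, so there is no direct precedent for the lengthening. With compound 1 sitting at the limit and no evidence that the chain matters, compound 4 is expected to stay at or near that limit, with the step of a number no higher from compound 1 to compound 4 (the limit leaves the size open) expected to lie within the scatter. The estimate for compound 4 in this assay is 100000 nM, in a range from 30000 nM to 300000 nM.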

Compound 4, concentration for 50% growth inhibition: 72300 nM
For compound 4 the middle estimate is 1.4-fold (0.14 log units) above the measured one, and the stated range covers the measured number.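

Among the compounds shown here, the lengthened chain gives the first reading at the position on a saturated chain carbon bound to a saturated ring carbon, since both earlier steps changed only the aryl substituent: in this assay the step is an at least 1.3-fold lower number from compound 1 to compound 4 (0.14 log units; that floor lies within the scatter). Compound 4 thus gives a measured number and not a limit, but the step has only a floor, and that floor does not separate the change from repeat-measurement noise, so the data show no clear effect of the added carbon and cannot rule out a larger one. The result also reduces the share of the set held at the assay's limit, though that limit remains common: the limit of > 100000 nM in this assay, at which 2 of the 4 values shown sit.

The compounds shown leave open whether a longer chain such as 3-(sulfamoylamino)propyl would continue this reading, and whether an amine or a carboxylic acid at the end of the chain would give a measurable number at all. They also leave open what the 2-(sulfamoylamino)ethyl chain would give when paired with the ethoxycarbonyl aryl substituent of compound 2, the one change shown so far with a step clearly beyond the scatter.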